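This account rests on a few compounds, and the source may have more. Where it says the series, first, only, none or still open, it means among the compounds named here.

Compound 1 `Cc1nc(N)sc1CCCN/C(N)=N/C(=O)NCC(C)CCc1ccccc1` is one of three compounds tested in an assay on membranes from Sf9 cells for displacement of a labelled ligand from histamine H2 receptor (Homo sapiens), read by scintillation counting, with a stated time of 60 min (on this read-out lower numbers stand for stronger inhibition and higher numbers for weaker inhibition), where compound 1 gives 63.1 nM. Compound 3 `CCC(NC(=O)/N=C(\N)NCCCc1sc(N)nc1C)c1ccccc1` gives 63.1 nM, the same number at the digits shown, so these two stand together as the highest numbers of the set, within the scatter of each other. Compound 2 `Cc1nc(N)sc1CCCN/C(N)=N/C(=O)NCc1ccco1` gives 10.5 nM, a lower number than compound 1 that lies beyond the scatter. Compound 4 `Cc1ccc(CC(C)CNC(=O)/N=C(\N)NCCCc2sc(N)nc2C)cc1` has the same atoms as compound 1, joined differently: 4-methylphenyl in place of benzyl on a saturated chain carbon, three bonds along the chain from an amide-type nitrogen. Among the compounds with values here, no pair of measured compounds shows this change, so its effect has no precedent here. The step of a 1.3-fold lower number from compound 1 to compound 4 (0.10 log units; within the scatter) is expected to be small, in no certain direction, and probably within the scatter. Compound 4 is therefore estimated at 50 nM, with a range from 15 nM to 160 nM.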

Compound 4, inhibition constant: 72.4 nM
For compound 4 the middle estimate is 1.4-fold (0.16 log units) below the measured one; the measured number falls inside the stated range.
By their numbers in this assay, from the lowest: compound 2; then compounds 1, 3 and 4 (each within the scatter of the next).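

Placing 4-methylphenyl in place of benzyl on a saturated chain carbon, three bonds along the chain from an amide-type nitrogen, gives a 1.1-fold higher number from compound 1 to compound 4 (0.06 log units; within the scatter) in this assay. Within the data shown here, this is the first comparison in the set between compounds that differ in one place, and it shows that this rearrangement of the same atoms keeps the two compounds indistinguishable on this read-out. Nothing presented here offers a reason for this result. Going by these compounds, whether an amine or a carboxylic acid in place of the methyl of compound 4 would stay within the scatter remains open.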